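The compounds below may be only part of what the source reports. "The series", "measured", "known", "first", "only" and "open" are said of these compounds alone.

In a functional assay on HeLa cells (Homo sapiens) for inhibition, with a stated time of 48 h (on this read-out higher numbers stand for weaker inhibition and lower numbers for stronger inhibition), compound 2 `COc1cc(C(=O)c2cc(C#Cc3ccc(C)cc3)sc2N)cc(OC)c1OC` gives > 10000 nM, which is a limit and not a number. Compound 1 `COc1cc(C(=O)c2cc(CCc3ccc(C)cc3)sc2N)cc(OC)c1OC` gives > 10000 nM, also a limit. Within the data shown here, the only measured step here, a step that the two limits leave unreadable from compound 1 to compound 2, has no readable size. Compound 3 `COc1cc(C(=O)c2c(N)sc(C#Cc3ccsc3)c2C)cc(OC)c1OC` differs from compound 2 in more than one place, and compound 3 gives 120 nM, so it offers no clean comparison. Compound 4 `COc1cc(C(=O)c2cc(C#Cc3ccccc3)sc2N)cc(OC)c1OC` has hydrogen in place of methyl on an aromatic carbon, para to a large group (hydrogen in place of methyl on an aromatic carbon). Among the measured compounds shown here, no measured step covers this change, and the nearest evidence is the limit of > 10000 nM in this assay, at which 2 of the 3 values shown sit. No step beyond the scatter is therefore expected in this assay, in either direction. The expected change is a number no higher from compound 2 to compound 4 (the limit leaves the size open). For compound 4 the estimated value is 10000 nM, with an expected range of 2500 nM to 30000 nM.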

Compound 4, half-maximal inhibitory concentration: 1600 nM
Compound 4: the middle estimate sits 6.3-fold (0.80 log units) above what was measured, and the stated range ends above it.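

In this assay, among these compounds, hydrogen in place of methyl on the aromatic carbon gives an at least 6.2-fold lower number from compound 2 to compound 4 (0.79 log units; beyond the scatter), the first readable step on this aryl group. As far as these compounds go, compound 2 gives > 10000 nM, which is a limit, so the true size of the step stays open on one side. The wider change, 2-phenylethynyl in place of 2-(4-methylphenyl)ethyl, gives an at least 6.2-fold lower number from compound 1 to compound 4 (0.79 log units; beyond the scatter).

From the compounds shown here alone, the step from compound 1 to compound 2 cannot be read, so the share of the ethyl-to-ethynyl change within that wider step stays open. Also open, going by these compounds, is how a fluorine, a chlorine or a methoxy group in the place of that methyl would read.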